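Removing the carboxy side chain from compound 3

This account rests on a few compounds, and the source may have more. Where it says the series, first, only, none or still open, it means among the compounds named here.

Compound 3 `O=C(O)COCc1nc(Nc2ccc(C(F)(F)F)cc2)c2ccc(-c3ncccc3C(F)(F)F)cc2n1` stands highest of the three measured compounds in a physicochemical assay for solubility, at pH 7.4 (a lower number here means a less soluble compound, a higher number a more soluble compound), at 125 ug/mL. Compound 1 `COCc1nc(Nc2ccc(C(F)(F)F)cc2)c2ccc(-c3ncccc3C(F)(F)F)cc2n1` gives 0.2 ug/mL, and compound 2 `CCOCc1nc(Nc2ccc(C(F)(F)F)cc2)c2ccc(-c3ncccc3C(F)(F)F)cc2n1` gives 0.6 ug/mL. Compound 4 `OCCCc1nc(Nc2ccc(C(F)(F)F)cc2)c2ccc(-c3ncccc3C(F)(F)F)cc2n1` keeps the shared core but differs from compound 3 in its side chain: 2-hydroxyethyl in place of carboxymethoxy on a saturated chain carbon bound to an aromatic carbon. Here 2-hydroxyethyl takes the place of carboxymethoxy on a saturated chain carbon bound to an aromatic carbon, so (carboxymethoxy)methyl becomes 3-hydroxypropyl.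

Among the compounds with values here, three measured steps bear on this change. Carboxy in place of hydrogen gave a 630-fold higher number from compound 1 to compound 3 (2.80 log units; beyond the scatter), and carboxy in place of methyl gave a 210-fold higher number from compound 2 to compound 3 (2.32 log units; beyond the scatter). Methyl in place of hydrogen gave only a 3.0-fold higher number from compound 1 to compound 2 (0.48 log units; beyond the scatter). Compound 4 has no carboxy, so most of the large rise seen with compound 3 should be lost. Within the data shown here, no measured compound here carries 2-hydroxyethyl, so its own contribution is unknown. A large fall is expected, an estimated 83-fold lower number from compound 3 to compound 4 (1.92 log units; beyond the scatter). The estimated value for compound 4 is 1.5 ug/mL, with an expected range of 0.3 ug/mL to 8 ug/mL.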

Compound 4, solubility: 0.06 ug/mL
Compound 4: middle estimate off by 25-fold (1.40 log units), on the high side; the whole stated range lies above it.
By their numbers in this assay, from the lowest: compound 4; then compound 1; then compound 2; then compound 3.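

Replacing carboxymethoxy with 2-hydroxyethyl gives a 2100-fold lower number from compound 3 to compound 4 (3.32 log units; beyond the scatter) in this assay, a fall that does not stop at the level of the two simple ethers. The hydroxy compound also lies under both of them, with a 10-fold lower number from compound 2 to compound 4 (1.00 log units; beyond the scatter) and a 3.3-fold lower number from compound 1 to compound 4 (0.52 log units; beyond the scatter), so compound 4 is the lowest of the four and a terminal hydroxy group on this chain does not recover any of the high number of compound 3. Nothing available here explains why compound 4 falls under the two ethers.

Compound 4 differs from the ethers in both its end group and its chain, so these two changes cannot be separated. Still open, going by these compounds, is what an amine or a primary amide at the end of this side chain would give, and whether a carboxylic acid on an all-carbon chain would match compound 3.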